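Compound 4: benzyl ring change on the shared core

The compounds below may be only part of what the source reports. "The series", "measured", "known", "first", "only" and "open" are said of these compounds alone.

Measured so far:
Compound 1, `COc1ccc(CN(C(=O)CSC(=S)N2CCCC2)c2cc(OC)c(OC)c(OC)c2)cc1`: 13800 nM
Compound 2, `COc1ccc(CN(C(=O)CSC(=S)N2CCc3cc(OC)ccc32)c2cc(OC)c(OC)c(OC)c2)cc1`: 10200 nM
Compound 3, `COc1cc(N(Cc2ccc(Cl)cc2)C(=O)CSC(=S)N2CCN(C(=O)OC(C)(C)C)CC2)cc(OC)c1OC`: 11900 nM

All three were run in a functional assay on KYSE-450 cells (Homo sapiens) for inhibition, read by CCK-8 assay, with a stated time of 48 h; on this read-out higher numbers stand for weaker inhibition and lower numbers for stronger inhibition. Compound 3 stands within the scatter of both compound 1 and compound 2, so the three numbers cannot be told apart. Compound 4, `COc1ccc(CN(C(=O)CSC(=S)N2CCN(C(=O)OC(C)(C)C)CC2)c2cc(OC)c(OC)c(OC)c2)cc1N`, differs from compound 3 by 3-amino-4-methoxyphenyl in place of 4-chlorophenyl on a saturated chain carbon bound to an amide-type nitrogen. Going by the values given here, the only measured step, a 1.4-fold lower number from compound 1 to compound 2 (0.13 log units; within the scatter), concerns the group on the thiocarbonyl carbon and stays within the scatter; no step touches the group on the saturated chain carbon bound to the amide-type nitrogen. Nothing therefore points to a move beyond the scatter in this assay, and the step is expected as a 1.0-fold higher number from compound 3 to compound 4 (0.00 log units; within the scatter), none beyond it. Compound 4 is estimated at 12000 nM, with a range from 5000 nM to 30000 nM.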

Compound 4, half-maximal inhibitory concentration: 208 nM
Estimate against measurement, compound 4: 58-fold (1.76 log units) above; measured number outside the range, below it.
By their numbers in this assay, from the lowest: compound 4; then compounds 2, 3 and 1 (each within the scatter of the next).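

In this assay, going by these compounds alone, the group on a saturated chain carbon bound to an amide-type nitrogen turns out to be a sensitive position: 3-amino-4-methoxyphenyl in place of 4-chlorophenyl gives a 57-fold lower number from compound 3 to compound 4 (1.76 log units; beyond the scatter) and is the first step beyond the scatter. The change removes the chlorine and brings in both an amino and a methoxy group, so this single step cannot separate their contributions. No evidence on hand bears on this result. Still open, going by these compounds, is whether a hydroxyl or an acetamide in place of the amino group would retain the low number. Also open, on these data alone, is whether the 3-amino-4-methoxybenzyl group gives a similar step with the pyrrolidine of compound 1 or the methoxyindoline of compound 2.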